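A cap exchange on a shared core, and solubility

The source may report more compounds than this note shows. Statements on the series, on what has been measured and on what is new or still open speak of the compounds shown alone.

Of the compounds shown here, two of one series have been measured in a physicochemical assay for solubility, in phosphate buffer, at pH 7.4 (a higher number here means a more soluble compound, a lower number a less soluble compound), so far. Compound 1 `N=C(N)c1ccc2[nH]c(-c3cccc(-c4cc(F)ccc4O)c3O)cc2c1` gives 83000 nM, and compound 2 `C=CCO/N=C(/N)c1ccc2[nH]c(-c3cccc(-c4ccccc4O)c3O)cc2c1` gives 24000 nM. For the measured compounds named here, on these two numbers compound 2 stands lowest; the only neighbour, compound 1, sits higher, and that gap lies beyond the usual scatter of repeated measurements. Nothing more can be read from the pair, since the two differ at more than one place.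

Compound 3 `CCOC(=O)NC(=N)c1ccc2[nH]c(-c3cccc(-c4ccccc4O)c3O)cc2c1` has not yet been measured in this assay. It departs from compound 2 at a single position: a group of 8 heavy atoms (4 carbon, 2 nitrogen, 2 oxygen; no ring) in place of a group of 7 heavy atoms (4 carbon, 2 nitrogen, 1 oxygen; no ring), on an aromatic carbon, on a six-membered aromatic ring of carbon only that belongs to a fused system of two rings, meta to one fused ring and para to the other. Going by the values given here, no step between measured compounds matches this exchange, so there is no measured precedent to lean on; the expectation rests on compound 2 alone, whose own value is 24000 nM.

For compound 3 a solubility of about 20000 nM is estimated, with a plausible range from 7000 nM to 60000 nM. The expected step from compound 2 to compound 3 is a 1.2-fold lower number from compound 2 to compound 3 (0.08 log units; within the scatter), which is not expected to exceed the scatter by much, if at all.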

Compound 3, solubility: < 10000 nM
Compound 3: a limit, no number; the forecaster's own chance of this, stated with the estimate: 5%; at least 2.0-fold (0.30 log units) between middle value and limit.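

In this assay compound 3 gives < 10000 nM, which is a limit of the assay and not a number. Even so, the step can be read as a first measured exchange at this position, on an aromatic carbon of the six-membered ring of the fused system, and it gives an at least 2.4-fold lower number from compound 2 to compound 3 (0.38 log units; beyond the scatter). So the position is not indifferent to which group it carries, even though the group that leaves and the group that enters both have no ring, no net charge and 2 double bonds outside aromatic rings, and the series now has a step here beyond the scatter rather than only a pair differing in more than one place.

As far as these compounds go, how large the step really is stays unknown, because compound 3 is reported only as a limit: the limit of < 10000 nM in this assay, at which 1 of the 3 values shown sits. A single exchange also cannot show which part of the entering group goes with the lower solubility, or how a simple amine or a carboxylic acid would behave on this same aromatic carbon.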